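The source may report more compounds than this note shows. Statements on the series, on what has been measured and on what is new or still open speak of the compounds shown alone.

Working notes on the series. In a functional assay on OCI-Ly7 cells (Homo sapiens) for antiproliferative activity, read by WST assay, with a stated time of 3 days (a higher number here means a weaker inhibitor, a lower number a stronger inhibitor), compound 1 (`O=c1cc(I)n([C@@H]2O[C@H](CO)[C@@H](O)[C@H]2O)c(=O)[nH]1`) gives > 50000 nM, which is a limit and not a number. Compound 2 (`Nc1cc(=O)[nH]c(=O)n1[C@@H]1O[C@H](CO)[C@@H](O)[C@H]1O`) gives > 50000 nM, also a limit. Compound 3 (`O=c1[nH]c(=O)n([C@@H]2O[C@H](CO)[C@@H](O)[C@H]2O)c(I)c1F`) gives > 50000 nM, again a limit, so its standing is known only as a limit. All readings so far sit at the limit of > 50000 nM in this assay, at which 3 of the 3 values shown sit.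

Compound 4 (`Nc1c(F)c(=O)[nH]c(=O)n1[C@@H]1O[C@H](CO)[C@@H](O)[C@H]1O`) remains unmeasured. It differs from compound 3 by amino in place of iodo on an aromatic carbon, next to the ring nitrogen and ortho to a fluoro group.

Within the data shown here, two measured steps bear on this change: a step that the two limits leave unreadable from compound 1 to compound 2, the same exchange without the fluoro group, and a step that the two limits leave unreadable from compound 1 to compound 3, the fluoro group itself. Neither has a readable size, so neither supports a direction in this assay, and no change beyond the scatter is expected. The expected step is a number no higher from compound 3 to compound 4 (the limit leaves the size open). Compound 4 is estimated at 50000 nM, with an expected range of 15000 nM to 80000 nM.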

Compound 4, half-maximal inhibitory concentration: 1300 nM
Compound 4: middle estimate off by 38-fold (1.59 log units), on the high side; measured number outside the range, below it.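

In this assay, amino in place of iodo on the aromatic carbon next to the ring nitrogen gives an at least 38-fold lower number from compound 3 to compound 4 (1.58 log units; beyond the scatter), and fluoro in place of hydrogen gives an at least 38-fold lower number from compound 2 to compound 4 (1.58 log units; beyond the scatter), so each group has a large effect when the other is present. Among the compounds shown, only the core carrying both amino and the fluoro group gives a number rather than a limit. Compound 1, compound 2 and compound 3 remain at a limit, and the steps among them cannot be read: the limit of > 50000 nM in this assay, at which 3 of the 4 values shown sit.

From the compounds shown here alone, the share of each group alone stays open: compound 2 and compound 3 give limits only. Going by these compounds, it is also open whether a methylamino group in place of amino, or a chloro group in place of fluoro, would preserve the number seen for compound 4.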